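Working notes on a methyl-to-cyano step

A few compounds are considered here, and "the series" means these few. Any claim that something is new, unique, unknown or untested is made for them only; others in the source may bear on it.

Measured so far:
compound 1, `COC(=O)c1ccc(NCc2cncn2Cc2ccccc2C)cc1-c1ccccc1`, in a toxicity assay on NIH3T3 cells (Mus musculus) for cytotoxicity, read by resazurin assay; on this read-out higher numbers stand for an effect only at larger amounts of compound and lower numbers for an effect already at smaller amounts: 10000 nM
compound 2, `CCc1ccc(Cn2cncc2CNc2ccc(-c3nc4ccccc4s3)c(-c3ccccc3)c2)cc1`, in this assay: > 1000 nM

Among the compounds with values here, compound 1 stands as the only compound with a number in this assay, 10000 nM; the other entry is not a number. For compound 2 the entry is a limit of the assay, > 1000 nM, so no number is known for it; this is the case described by the limit of > 1000 nM in this assay, at which 1 of the 2 values shown sits. Within the data shown here, no two measured compounds differ in one place, so no measured step exists. Compound 3, `COC(=O)c1ccc(NCc2cncn2Cc2ccccc2C#N)cc1-c1ccccc1`, is still to be measured; it differs from compound 1 by cyano in place of methyl on an aromatic carbon, a cyano group entering where a methyl leaves. Among the measured compounds shown here, no measured precedent for such a change is available here, and the expectation for this assay is no step beyond the scatter, no change at the digits printed from compound 1 to compound 3 (within the scatter). The value expected for compound 3 in this assay is 10000 nM, with a range from 4000 nM to 25000 nM.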

Compound 3, half-maximal effective concentration: 25000 nM
For compound 3 the middle estimate is 2.5-fold (0.40 log units) below the measured one; the measured number falls inside the stated range.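

Cyano in place of methyl on an aromatic carbon, ortho to a large group, gives in this assay a 2.5-fold higher number from compound 1 to compound 3 (0.40 log units; beyond the scatter), the first readable step in the series. This position therefore responds to the change on this read-out, with the effect of the 2-cyanobenzyl compound appearing only at larger amounts than that of its 2-methylbenzyl partner. Nothing at hand bears on why the step occurs.

Whether the step belongs to the cyano group itself or would follow other replacements of methyl stays open, with a chlorine, a methoxy group or an amine at this place not among the compounds shown. Also open, as far as these compounds go, is whether the same change would give a step of like size on another core, such as that of compound 2, whose entry of > 1000 nM is a limit of the assay and not a number.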